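Swapping the Benzyl Substituent of an Inactive Urea

The source may hold more compounds than are shown below. What is called first, only, known or untested is meant among the compounds shown, and "the series" means these compounds.

Compound 1 `NC(=O)N1CCN(C(=S)SCc2cn(Cc3ccccc3F)nn2)CC1` carries an unsubstituted urea on the shared core. In a functional assay on MCF7 cells (Homo sapiens) for cytotoxicity, read by MTT assay, with a stated time of 72 h (on this read-out higher numbers stand for weaker inhibition and lower numbers for stronger inhibition), compound 1 gives > 128000 nM, and this is a limit of the assay rather than a measured number. Its two measured relatives vary the amide-type nitrogen instead. Compound 2 `CCNC(=O)N1CCN(C(=S)SCc2cn(Cc3ccccc3F)nn2)CC1`, with an ethyl group on that nitrogen, gives 5760 nM in this assay. Compound 3 `O=C(NC1CCCCC1)N1CCN(C(=S)SCc2cn(Cc3ccccc3F)nn2)CC1`, with a cyclohexyl group there, gives 85000 nM. The move from the bare nitrogen to ethyl brings an at least 22-fold lower number from compound 1 to compound 2 (1.34 log units; beyond the scatter), and enlarging ethyl to cyclohexyl brings a 15-fold higher number from compound 2 to compound 3 (1.17 log units; beyond the scatter); the direct comparison of the two ends shows an at least 1.5-fold lower number from compound 1 to compound 3 (0.17 log units; that floor lies within the scatter).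

Compound 4 `Cc1ccc(Cn2cc(CSC(=S)N3CCN(C(N)=O)CC3)nn2)cc1` keeps the unsubstituted urea of compound 1 and instead alters the other end of the molecule: 4-methylphenyl in place of 2-fluorophenyl on a saturated chain carbon bound to an aromatic nitrogen. None of the three measured steps touches this position; all concern the amide-type nitrogen, so they give no direct guide to the size or direction of the present change. What they do show is that with the bare urea, as in compound 1, the number sits at the limit of > 128000 nM in this assay, at which 1 of the 3 values shown sits. In this assay compound 4 is therefore expected to show a step that the limit leaves unreadable from compound 1 to compound 4, and its value is estimated at 150000 nM, within a range from 40000 nM to 500000 nM.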

Compound 4, half-maximal inhibitory concentration: > 128000 nM
Compound 4: only a limit was reported (the forecaster's own chance of this, stated with the estimate: 70%); the middle value lies beyond the limit too.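

Compound 1 and compound 4 both end at a limit of the assay rather than a measured number, so no step between them can be read: the limit of > 128000 nM in this assay, at which 2 of the 4 values shown sit.

The compounds shown leave open whether 4-methylphenyl in place of 2-fluorophenyl shifts the number at all, and what that swap would do alongside the ethyl group of compound 2.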